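A few compounds are considered here, and "the series" means these few. Any claim that something is new, unique, unknown or untested is made for them only; others in the source may bear on it.

Of the compounds shown here, two have been measured in a functional assay on HL-60 cells (Homo sapiens) for inhibition, read by XTT assay, with a stated time of 72 h; on this read-out lower numbers stand for stronger inhibition and higher numbers for weaker inhibition. Compound 1 `OC[C@H]1O[C@@H](n2cnc3c(CSCc4ccccc4)ncnc32)[C@H](O)[C@@H]1O` gives 19200 nM, and compound 2 `COCc1ncnc2c1ncn2[C@@H]1O[C@H](CO)[C@@H](O)[C@H]1O` gives 1680 nM, the lower of the two numbers. Among the compounds with values here, the single recorded step, an 11-fold lower number from compound 1 to compound 2 (1.06 log units; beyond the scatter), came with methoxy in place of benzylsulfanyl on a saturated chain carbon bound to an aromatic carbon. Compound 3 `CSCc1ncnc2c1ncn2[C@@H]1O[C@H](CO)[C@@H](O)[C@H]1O` differs from compound 2 by methylsulfanyl in place of methoxy on a saturated chain carbon bound to an aromatic carbon. The recorded step bears on this change only in part: it swapped oxygen for sulfur while also shedding the benzyl portion, so a smaller move in the same direction as the reverse is expected. Compound 3 is therefore estimated at 4000 nM, within 1500 nM to 12000 nM, as a 2.4-fold higher number from compound 2 to compound 3 (0.38 log units; beyond the scatter).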

Compound 3, half-maximal inhibitory concentration: 5000 nM
Beside the measured number, compound 3's estimate is 1.3-fold (0.10 log units) below it, and the stated range covers the measured number.
By their numbers in this assay, from the lowest: compound 2; then compound 3; then compound 1.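

In this assay, methylsulfanyl in place of methoxy gives a 3.0-fold higher number from compound 2 to compound 3 (0.47 log units; beyond the scatter), so the exchange of oxygen for sulfur at this saturated chain carbon bound to an aromatic carbon can now be read without the benzyl portion. Hydrogen in place of phenyl on the carbon bound to sulfur gives a 3.8-fold lower number from compound 1 to compound 3 (0.58 log units; beyond the scatter), so the large gap between compound 1 and compound 2 divides into two modest steps, both beyond the scatter. No measurement shown here explains either step. The compounds shown leave open how an amine or a longer chain such as ethoxy in place of methoxy would compare with compound 2.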